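Methyl on the thiophene-bound phenyl of compound 2

This account rests on a few compounds, and the source may have more. Where it says the series, first, only, none or still open, it means among the compounds named here.

Compound 2 `O=C(NNC(=S)Nc1csc(-c2ccccc2)c1)c1ccc(O)cc1` gives 78000 nM in a functional assay on MCF7 cells (Homo sapiens) for inhibition, read by colorimetric assay and MTT assay, with a stated time of 72 h (on this read-out lower numbers stand for stronger inhibition and higher numbers for weaker inhibition), the higher of the two numbers seen so far; compound 1 `Cc1ccc(C(=O)NNC(=S)Nc2csc(-c3ccc(C)cc3)c2)cc1` gives 29000 nM in this assay, and the gap between the two lies beyond the scatter. Compound 3 `Cc1ccc(-c2cc(NC(=S)NNC(=O)c3ccc(O)cc3)cs2)cc1` carries methyl in place of hydrogen on an aromatic carbon. Among the compounds with values here, no step of exactly this kind has been measured. A step toward a lower number is expected, of modest size, from compound 2 to compound 3, as a 1.6-fold lower number from compound 2 to compound 3 (0.19 log units; within the scatter). For compound 3 the expected value in this assay is 50000 nM, between 20000 nM and 120000 nM.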

Compound 3, half-maximal inhibitory concentration: 42000 nM
Estimate against measurement, compound 3: 1.2-fold (0.08 log units) above; the measured number falls inside the stated range.
By their numbers in this assay, from the lowest: compounds 1, 3 and 2 (each within the scatter of the next, the first and the last beyond it).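

In this assay the change from phenyl to 4-methylphenyl gives a 1.9-fold lower number from compound 2 to compound 3 (0.27 log units; within the scatter), so a methyl at this place, para to a large group, leaves the number within the scatter. The other single change, hydroxy in place of methyl on an aromatic carbon, gives a 1.4-fold higher number from compound 1 to compound 3 (0.16 log units; within the scatter), so it too stays within the scatter. Nothing available bears on the cause of either step.

Open, on these data alone, is whether methoxy or chloro at this place would give a step beyond the scatter. Also open, as far as these compounds go, is how an amine in place of the hydroxy would read.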